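This account rests on a few compounds, and the source may have more. Where it says the series, first, only, none or still open, it means among the compounds named here.

In a functional assay on HepG2 cells (Homo sapiens) for cytotoxicity, read by MTT assay, with a stated time of 24 h (on this read-out higher numbers stand for weaker inhibition and lower numbers for stronger inhibition), compound 1 (`Cc1ccc(S(=O)(=O)N2C/C(=C\c3cccnc3)C(=O)/C(=C/c3ccccc3C(F)(F)F)C2)cc1`) gives 2930 nM and compound 2 (`O=C1/C(=C/c2ccncc2)CNC/C1=C\c1ccccc1C(F)(F)F`) gives 6130 nM. Compound 2 therefore has the higher of the two numbers, with compound 1 lower by more than the scatter. Compound 3 (`Cc1ccc(S(=O)(=O)N2C/C(=C\c3ccncc3)C(=O)/C(=C/c3ccccc3C(F)(F)F)C2)cc1`) departs from compound 2 by one change: (4-methylphenyl)sulfonyl in place of hydrogen on an amine nitrogen in a ring. Compound 1 also carries (4-methylphenyl)sulfonyl and gives 2930 nM, so a modest drop in the number is expected in this assay, slightly beyond the scatter. The expected change is a 2.0-fold lower number from compound 2 to compound 3 (0.31 log units; beyond the scatter). For compound 3, the estimated value is 3000 nM, with an expected range of 1300 nM to 6500 nM.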

Compound 3, half-maximal inhibitory concentration: 4640 nM
For compound 3 the middle estimate is 1.5-fold (0.19 log units) below the measured one; measured number inside the range.
By their numbers in this assay, from the lowest: compounds 1, 3 and 2 (each within the scatter of the next, the first and the last beyond it).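

In this assay, (4-methylphenyl)sulfonyl in place of hydrogen on the amine nitrogen in the ring does not separate the pair with pyridin-4-yl on the chain (a 1.3-fold lower number from compound 2 to compound 3 (0.12 log units; within the scatter)). With (4-methylphenyl)sulfonyl held fixed, pyridin-4-yl in place of pyridin-3-yl does not separate its pair either (a 1.6-fold higher number from compound 1 to compound 3 (0.20 log units; within the scatter)). Nothing available gives a cause for either step. Open, as far as these compounds go, is how an acetyl or methyl group on that nitrogen would read, and whether an unsubstituted phenyl in place of the pyridinyl group would shift the number.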